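A few compounds are considered here, and "the series" means these few. Any claim that something is new, unique, unknown or untested is made for them only; others in the source may bear on it.

Compound 1 `CC(C)C[C@H](NC(=O)CC[C@H](NC(=O)[C@H](C)NC(=O)OC(C)(C)C)C(=O)NCc1ccc2ccccc2c1)B(O)O`: 2350 nM
Compound 2 `CC(C)C[C@H](NC(=O)CCC[C@H](NC(=O)CNC(=O)OC(C)(C)C)C(=O)NCc1ccc2ccccc2c1)B(O)O`: > 10000 nM (a limit)
Compound 3 `CC(C)C[C@H](NC(=O)C[C@H](NC(=O)OC(C)(C)C)C(=O)NCc1ccc2ccccc2c1)B(O)O`: > 10000 nM (a limit)

Going by the values given here, in a functional assay on HeLa cells (Homo sapiens) for inhibition, read by MTT assay, with a stated time of 72 h (a lower number here means a stronger inhibitor, a higher number a weaker inhibitor), compound 1 gives 2350 nM, the only true number among the three measured compounds. Compound 2 is recorded at > 10000 nM, which is a limit and not a number. Compound 3 is recorded at > 10000 nM, which is also a limit.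

Compound 4 `CC(C)C[C@H](NC(=O)CC[C@H](NC(=O)CNC(=O)OC(C)(C)C)C(=O)NCc1ccc2ccccc2c1)B(O)O` has not yet been measured. It differs from compound 1 as follows: hydrogen in place of methyl on a saturated chain carbon bound to an amide-type nitrogen and a carbonyl carbon. In words, this is hydrogen in place of methyl on a saturated chain carbon bound to an amide-type nitrogen and a carbonyl carbon.

Among the compounds with values here, no measured pair shows this change alone, so its size can only be estimated. The expected change is a 1.6-fold higher number from compound 1 to compound 4 (0.21 log units; within the scatter) in this assay, a small lean toward weaker inhibition that stays within the scatter. That expected direction rests on (the limit of > 10000 nM in this assay, at which 2 of the 3 values shown sit). For compound 4 the estimated value is 3800 nM, with an expected range of 1500 nM to 10000 nM.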

Compound 4, half-maximal inhibitory concentration: 350 nM
For compound 4 the middle estimate is 11-fold (1.04 log units) above the measured one, outside the stated range (below it).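

In this assay, going by these compounds alone, hydrogen in place of methyl on the saturated chain carbon bound to an amide-type nitrogen and a carbonyl carbon gives a 6.7-fold lower number from compound 1 to compound 4 (0.83 log units; beyond the scatter), showing that this single methyl has a clear bearing on the value, which the earlier compounds could not show. With that hydrogen in place, a group of 11 heavy atoms in place of a group of 12 heavy atoms gives an at least 28-fold lower number from compound 2 to compound 4 (1.45 log units; beyond the scatter), so the chain carrying the boronic acid matters too. Compound 2 carries a limit and not a number, so this second step gives only a bound: the limit of > 10000 nM in this assay, at which 2 of the 4 values shown sit.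

The compounds shown leave open how an ethyl, an amine or a carboxylic acid on this same carbon would compare with hydrogen. As far as these compounds go, they also rest the methyl-to-hydrogen change on one pair, so whether it holds with a longer chain is unknown.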